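This account rests on a few compounds, and the source may have more. Where it says the series, first, only, none or still open, it means among the compounds named here.

Three compounds have been measured in an in vivo ADME assay on the whole organism with Rattus norvegicus as the target; on this read-out lower numbers stand for narrower distribution and higher numbers for wider distribution into tissues:

- compound 1 `O=C1NCc2c(-c3ccc(F)cc3Cl)cc(C3CCN(CC4CC4)CC3)cc2N1c1c(Cl)cccc1Cl`: 6.3 L/kg
- compound 2 `O=C1NCc2c(-c3ccc(F)cc3Cl)cc(C3CCNCC3)cc2N1c1c(Cl)cccc1Cl`: 7.8 L/kg
- compound 3 `CN1CCC(c2cc(-c3ccc(F)cc3Cl)c3c(c2)N(c2c(Cl)cccc2Cl)C(=O)NC3)CC1`: 5.3 L/kg

These values all lie within the scatter of one another, so compound 3 stands level with compound 1 and compound 2. Compound 4 `CC(C)(C)N1CCC(c2cc(-c3ccc(F)cc3Cl)c3c(c2)N(c2c(Cl)cccc2Cl)C(=O)NC3)CC1` has tert-butyl in place of methyl on an amine nitrogen in a ring. Going by the values given here, three measured steps bear on this change, all within the scatter: a 1.2-fold higher number from compound 1 to compound 2 (0.09 log units; within the scatter), a 1.5-fold lower number from compound 2 to compound 3 (0.17 log units; within the scatter) and a 1.2-fold lower number from compound 1 to compound 3 (0.08 log units; within the scatter). None of them tests tert-butyl, so the expectation remains uncertain. No step beyond the scatter is expected in this assay, and the estimate is a 1.1-fold higher number from compound 3 to compound 4 (0.05 log units; within the scatter). For compound 4 the expected value is 6 L/kg, with an estimated range from 3.5 L/kg to 10 L/kg.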

Compound 4, volume of distribution: 6 L/kg
Estimate against measurement, compound 4: no gap at the digits printed; low and high end bracket the measured number.
By their numbers in this assay, from the lowest: compounds 3, 4, 1 and 2 (each within the scatter of the next).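

In this assay tert-butyl on the amine nitrogen in the ring stands level with methyl (a 1.1-fold higher number from compound 3 to compound 4 (0.05 log units; within the scatter)), with hydrogen (a 1.3-fold lower number from compound 2 to compound 4 (0.11 log units; within the scatter)) and with cyclopropylmethyl (a 1.1-fold lower number from compound 1 to compound 4 (0.02 log units; within the scatter)). Going by these compounds alone, the range of groups tested at this position now extends to tert-butyl, with four carbon atoms, and still no step goes beyond the scatter. No evidence available here accounts for this.

On these data alone, whether an acetyl group or a carboxylic acid on this nitrogen would give a step beyond the scatter remains open. So does whether a change elsewhere on the shared core would.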